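A few compounds are considered here, and "the series" means these few. Any claim that something is new, unique, unknown or untested is made for them only; others in the source may bear on it.

Measured compounds and their values:

Compound 1, `CCCCCCCCCCCCCC[C@H](OCOC)[C@H](CO[Si](c1ccccc1)(c1ccccc1)C(C)(C)C)NC(=O)OC(C)(C)C`: in a functional assay on MCF7 cells (Homo sapiens) for antiproliferative activity, read by sulforhodamine B assay, with a stated time of 48 h, tested at 10 uM (a lower number here means less inhibition, a higher number more inhibition at the concentration tested (going by the name of the read-out)), compound 1 gives -7.95%.
Compound 2, `CCCCCCCCCCCCCC[C@H](OCOC)[C@H](CO)NC(=O)OC(C)(C)C`: in this assay compound 2 gives 10.2%.
Compound 3, `CCCCCCCCCCCCCC[C@H](OCOC)[C@H](CN(CC)CC)NC(=O)OC(C)(C)C`: in this assay compound 3 gives 25.3%.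

Compound 3 stands highest of the three in this assay, beyond the scatter from both compound 2 and compound 1. Among the measured compounds shown here, the one step that can be compared here is a number 15.1 percentage points higher from compound 2 to compound 3 (beyond the scatter), a modest rise that accompanies the exchange of hydroxy for diethylamino at the same place on the chain.

Compound 4, `CCCCCCCCCCCCCC[C@H](OCOC)[C@H](CN(C(C)C)C(C)C)NC(=O)OC(C)(C)C`, has not yet been measured. It differs from compound 3 as follows: diisopropylamino in place of diethylamino on a saturated chain carbon, two bonds along the chain from an amide-type nitrogen. For the measured compounds named here, no measured step shows what enlarging the amine at this place does; the only related step, from compound 2 to compound 3, concerns introducing the amine rather than varying it. As far as these compounds go, the expectation for compound 4 is therefore a number close to that of compound 3, with a number 4.7 percentage points higher from compound 3 to compound 4 (within the scatter) expected to lie within the scatter, though either direction remains open. Compound 4 is estimated at 30%, in the range 10% to 50%.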

Compound 4, a percentage reported as inhibition, at one concentration (the size of the read-out at that concentration, not a potency): 26.9%
For compound 4 the middle estimate is 3.1 percentage points above the measured one; the measured number falls inside the stated range.
By their numbers in this assay, from the lowest: compound 1; then compound 2; then compounds 3 and 4 (each within the scatter of the next).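

In this assay, diisopropylamino and diethylamino on a saturated chain carbon, two bonds along the chain from an amide-type nitrogen, cannot be told apart: the step is a number 1.6 percentage points higher from compound 3 to compound 4 (within the scatter), so the larger of these two amines brings no readable difference at this place. The second amine also stands clear of hydroxy, with a number 16.7 percentage points higher from compound 2 to compound 4 (beyond the scatter), so the rise seen with diethylamino is now seen with both amines shown. Nothing at hand explains why the two amines read alike or why either stands above hydroxy.

The compounds shown leave open how a ring amine such as piperidine or morpholine, or an unsubstituted amino group, would read at this place. Also open, as far as these compounds go, is what a carboxylic acid would give there.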